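A few compounds are considered here, and "the series" means these few. Any claim that something is new, unique, unknown or untested is made for them only; others in the source may bear on it.

Working notes on the series. The shared core is carried by compound 1 `CCOC(=O)/C=C1/C(=O)Nc2ccccc21`, compound 2 `CC(C)(C)OC(=O)/C=C1/C(=O)Nc2ccccc21` and compound 3 `CC(C)(C)OC(=O)/C=C1/C(=O)N(Cc2ccccc2)c2ccccc21`. In a functional assay on MDA-MB-231 cells (Homo sapiens) for inhibition, read by CCK-8 assay, with a stated time of 72 h, tested at 20 uM (a lower number here means less inhibition of growth, a higher number more inhibition of growth at the concentration tested), compound 1 gives 86.9%, compound 2 gives 87.6% and compound 3 gives 87.1%. Both measured steps, a number 0.7 percentage points higher from compound 1 to compound 2 (within the scatter) and a number 0.5 percentage points lower from compound 2 to compound 3 (within the scatter), lie within the scatter, so the three numbers cannot be told apart. On the numbers shown compound 2 stands highest of the three, with compound 3 nearest and compound 1 furthest, both within the scatter.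

Compound 4 `CN1C(=O)/C(=C/C(=O)OC(C)(C)C)c2ccccc21` differs from compound 2 in one place: methyl in place of hydrogen on an amide-type nitrogen in a ring. The measured step that bears on this change is a number 0.5 percentage points lower from compound 2 to compound 3 (within the scatter), which concerns the same amide-type nitrogen in a ring, there with benzyl in place of hydrogen; it did not move the number beyond the scatter. With methyl rather than benzyl entering, no step beyond the scatter is expected in this assay either, and the estimated step is a number 0.1 percentage points lower from compound 2 to compound 4 (within the scatter). Compound 4 is accordingly expected to give about 87.5% in this assay, with a range from 80% to 93%.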

Compound 4, percent growth inhibition at one concentration: 86.6%
Compound 4: middle estimate off by 0.9 percentage points, on the high side; the measured number falls inside the stated range.
By their numbers in this assay, from the lowest: compounds 4, 1, 3 and 2 (each within the scatter of the next).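

In this assay the amide-type nitrogen in a ring has now been read with hydrogen, methyl and benzyl, and a number 1 percentage points lower from compound 2 to compound 4 (within the scatter) stays inside the scatter just as the benzyl step did, so neither substituent separates from the hydrogen compound on the numbers shown. The direct comparison of the two substituted compounds, a number 0.5 percentage points lower from compound 3 to compound 4 (within the scatter), adds that removing the phenyl from the saturated chain carbon bound to this nitrogen also gives no readable change, which means that in these three compounds the number does not follow the group placed on this nitrogen. No measurement is available that would account for this flat result.

All four compounds are compared at a single tested concentration, so any difference that would appear at lower concentrations cannot be read from these values. From the compounds shown here alone, it remains open whether a group of another kind on this nitrogen, such as a longer chain ending in an amine or a carboxylic acid, would move the number beyond the scatter, and whether a carboxylic acid in place of the ester would do so.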